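Saturating the exocyclic double bond in the prenyl-type chain

The source may report more compounds than this note shows. Statements on the series, on what has been measured and on what is new or still open speak of the compounds shown alone.

Three compounds of the series have been run in an assay on HEK293 cells for inhibition of Voltage-dependent T-type calcium channel subunit alpha-1H (Homo sapiens), read by patch clamp, with a stated time of 10 min; on this read-out higher numbers stand for weaker inhibition and lower numbers for stronger inhibition. Compound 1 `CC(C)=CCc1c(O)cc2c(c1O)C(=O)CC(c1ccccc1O)O2` gives 640 nM. Within the data shown here, compound 2 `CC(C)=CCc1c(O)cc2c(c1O)C(=O)CC(c1cccc(O)c1)O2` gives 1020 nM; the single recorded step, a 1.6-fold higher number from compound 1 to compound 2 (0.20 log units; within the scatter), concerns the hydroxyphenyl on the saturated ring carbon only. Compound 3 `O=C1CC(c2ccc(O)cc2)Oc2cc(O)c(CC=C3CCCC3)c(O)c21` gives 460 nM, the lowest of the three numbers; its distance to compound 1 is within the scatter, its distance to compound 2 is beyond it, so compound 3 cannot be set apart from compound 1 on these data.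

Compound 4 `O=C1CC(c2ccc(O)cc2)Oc2cc(O)c(CCC3CCCC3)c(O)c21` differs from compound 3 in one place: a group of 6 heavy atoms (6 carbon; one five-membered non-aromatic ring of carbon only) in place of a group of 6 heavy atoms (6 carbon; one five-membered non-aromatic ring of carbon only), on a saturated chain carbon bound to an aromatic carbon. The change removes the one double bond outside aromatic rings and leaves everything else in the core unchanged. Among the measured compounds shown here, no measured step in this assay touches the chain bound to the aromatic carbon; the only recorded step moves a hydroxyl on the aryl ring and is itself within the scatter. There is therefore nothing in the data to support a move in either direction, and no step beyond the scatter is expected.

For compound 4 the expected value in this assay is 500 nM, with a range from 200 nM to 1300 nM. This estimate corresponds to an expected step of a 1.1-fold higher number from compound 3 to compound 4 (0.04 log units; within the scatter), taken as essentially flat.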

Compound 4, half-maximal inhibitory concentration: 500 nM
For compound 4 middle estimate and measured number coincide at the digits printed; the range from low to high includes it.
By their numbers in this assay, from the lowest: compounds 3, 4, 1 and 2 (each within the scatter of the next, the first and the last beyond it).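

Read through this assay, the change gives a 1.1-fold higher number from compound 3 to compound 4 (0.04 log units; within the scatter), the first step in the series to touch the group on a saturated chain carbon bound to an aromatic carbon, as the earlier step only moved a hydroxyl on the aryl ring. For this pair, the one double bond outside aromatic rings can therefore be removed without a step beyond the scatter, and cyclopentylmethyl serves here as well as the unsaturated group it replaces. No supporting evidence bears on why the step is flat, so the result stands as an observation on this one pair.

On these data alone, a single flat step does not show how much variation this position accepts: whether a longer chain, a cyclohexyl ring in place of the cyclopentyl ring, or an amine or a carboxylic acid on that ring would also leave the number unchanged stays open. Also open, as far as these compounds go, is whether saturating the chain would read the same in compound 1 and compound 2, where the hydroxyl sits differently on the aryl ring and the chain ends in a different group.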